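Removing a Nitro Group: Cytotoxicity Expected Unchanged

A few compounds are considered here, and "the series" means these few. Any claim that something is new, unique, unknown or untested is made for them only; others in the source may bear on it.

Three compounds built on one shared core were tested in an ADME assay on RAW264.7 cells (Mus musculus) for cytotoxicity, read by MTT assay, with a stated time of 48 h; on this read-out higher numbers stand for lower toxicity in this test and lower numbers for higher toxicity in this test. Compound 1 `CC(=O)OC[C@H]1O[C@H](OC[C@H](Cn2cc(COc3ccc(-c4noc(NC5CCCCC5)n4)cc3)nn2)OC(C)=O)C=C[C@@H]1OC(C)=O` gives 33.3 ug/mL, compound 2 `CC(=O)OC[C@H]1O[C@H](OC[C@H](Cn2cc(COc3ccc(-c4noc(C)n4)cc3)nn2)OC(C)=O)C=C[C@@H]1OC(C)=O` gives 112 ug/mL, and compound 3 `CC(=O)OC[C@H]1O[C@H](OC[C@@H](Cn2cc(CN(c3nc(-c4ccc([N+](=O)[O-])cc4)no3)C3CCCCC3)nn2)OC(C)=O)C=C[C@@H]1OC(C)=O` gives 64.1 ug/mL, which places compound 3 second highest of the three numbers, although it sits within the scatter of both others. Within the data shown here, the only single-change step among them, a 3.4-fold higher number from compound 1 to compound 2 (0.53 log units; beyond the scatter), exchanges one group for another on an aromatic carbon. Compound 4 `CC(=O)OC[C@H]1O[C@H](OC[C@@H](Cn2cc(CN(c3nc(-c4ccccc4)no3)C3CCCCC3)nn2)OC(C)=O)C=C[C@@H]1OC(C)=O` differs from compound 3 by hydrogen in place of nitro on an aromatic carbon. Among the measured compounds shown here, this change has no counterpart among the measured steps, so the expected step is none beyond the scatter, a 1.0-fold lower number from compound 3 to compound 4 (0.00 log units; within the scatter). Compound 4 is therefore estimated at 64 ug/mL, with a range from 25 ug/mL to 160 ug/mL in this assay.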

Compound 4, half-maximal cytotoxic concentration: 28.6 ug/mL
Estimate against measurement, compound 4: 2.2-fold (0.35 log units) above; measured number inside the range.
By their numbers in this assay, from the lowest: compounds 4, 1, 3 and 2 (each within the scatter of the next, the first and the last beyond it).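

Replacing nitro with hydrogen, which turns 4-nitrophenyl into phenyl, gives a 2.2-fold lower number from compound 3 to compound 4 (0.35 log units; beyond the scatter) in this assay. This shows that the read-out responds to a change at this place on the aromatic ring, with the lower number standing for higher toxicity in this test. No measured evidence here explains the step. The compounds shown leave open how another group at this place, such as an amine or a carboxylic acid, would read, and whether the number depends on nitro specifically or on any group there.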